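The source may hold more compounds than are shown below. What is called first, only, known or untested is meant among the compounds shown, and "the series" means these compounds.

Working notes on the series. Among the compounds with values here, the three compounds measured so far share a core in which an amidrazone is joined to a thiourea; they differ in the amine ring at the thiourea end and in the aromatic ring at the amidrazone end. Compound 1 is `Cc1ccnc(/C(N)=N/NC(=S)N2CCCC2)c1`, compound 2 is `N/C(=N\NC(=S)N1CCN(c2ccccn2)CC1)c1ccc(F)cn1`, and compound 3 is `N/C(=N\NC(=S)N1CCCCCC1)c1ccccn1`. In a functional assay on MCF7 cells (Homo sapiens) for cytotoxicity, read by MTT assay, with a stated time of 72 h, tested at 100 uM (a higher number here means more inhibition of growth at the concentration tested, a lower number less inhibition of growth), compound 1 gives 87.7%, compound 3 gives 84%, and compound 2 gives 74.3%, the lowest of the three numbers. The gap from compound 2 to compound 3 lies within the scatter of repeated runs; the gap from compound 2 to compound 1 lies beyond it.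

The next compound, compound 4, is `N/C(=N\NC(=S)N1CCN(c2ccccn2)CC1)c1ccccn1`. It keeps the amine ring of compound 2 and alters only the aromatic ring: hydrogen in place of fluoro on an aromatic carbon. Within the data shown here, no pair measured so far differs in this single place, so there is no measured step to lean on. Among the measured compounds shown here, the change is small, one heavy atom, and the only other compounds carrying the pyridin-2-yl ring, compound 1 and compound 3, were read somewhat higher than compound 2. A modest rise is expected, if any, and the expected step from compound 2 to compound 4 in this assay is a number 3.7 percentage points higher from compound 2 to compound 4 (within the scatter), within the scatter. Compound 4 is therefore estimated at 78%, with a plausible range from 63% to 91%.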

Compound 4, percent growth inhibition at one concentration: 68.3%
Beside the measured number, compound 4's estimate is 9.7 percentage points above it; measured number inside the range.
By their numbers in this assay, from the lowest: compounds 4, 2, 3 and 1 (each within the scatter of the next, the first and the last beyond it).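

In this assay, within the data shown here, this pair gives the first single-place reading at this aromatic carbon: a number 6 percentage points lower from compound 2 to compound 4 (within the scatter), with the amine ring held constant. Fluoro and hydrogen at this position are therefore not separated by this assay, and the pair gives no sign that the 5-fluoropyridin-2-yl to pyridin-2-yl change matters here, at least with this amine ring. No measurement at hand speaks to the origin of this small step.

Going by these compounds, it remains open whether a larger replacement at the same carbon, such as methoxy, an amine or a carboxylic acid, would produce a step beyond the scatter. Also open, on these data alone, is whether the same exchange of fluoro for hydrogen would read the same way with a different amine ring at the thiourea end.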